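Working notes: from compound 3 to compound 4

This account rests on a few compounds, and the source may have more. Where it says the series, first, only, none or still open, it means among the compounds named here.

Measured in a functional assay on DLD-1 cells (Homo sapiens) for antiproliferative activity, read by CellTiter-Glo, with a stated time of 72 h; a higher number here means a weaker inhibitor, a lower number a stronger inhibitor:

compound 1 `CCc1ccc(S(=O)(=O)N2CCC(N3CCC(C)CC3)CC2)cc1` — > 5000 nM
compound 2 `CC1CCN(C2CCN(S(=O)(=O)c3cccnc3Cl)CC2)CC1` — > 5000 nM
compound 3 `CC1CCN(C2CCN(S(=O)(=O)c3ccc(OCc4ccccc4)cc3)CC2)CC1` — 385 nM

Compound 1 returns only a limit of this assay, not a number. Compound 2 likewise returns only a limit. For the measured compounds named here, compound 3 is the one compound with a number; the two other values are limits (the limit of > 5000 nM in this assay, at which 2 of the 3 values shown sit). The step that the two limits leave unreadable from compound 1 to compound 2 therefore cannot be read. Going by the values given here, the step of an at least 12-fold lower number from compound 1 to compound 3 (1.11 log units; beyond the scatter) is the single readable step in the set, and it is large.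

Compound 4 `CCCOc1ccc(S(=O)(=O)N2CCC(N3CCC(C)CC3)CC2)cc1` differs from compound 3 in one place: ethyl in place of phenyl on a saturated chain carbon bound to an oxygen on an aromatic ring. The change runs toward compound 1, since the benzyloxy that gave the large drop from compound 1 to compound 3 loses its phenyl, while the oxygen on the aromatic ring stays. Among the compounds with values here, the only relevant step is that from compound 1 to compound 3; the propoxy of compound 4 lies between the ethyl of compound 1 and the benzyloxy of compound 3, so an upward step beyond the scatter, smaller than the full reverse of that step, is expected.

For compound 4 the expected step is a 5.2-fold higher number from compound 3 to compound 4 (0.72 log units; beyond the scatter). Compound 4 is estimated at 2000 nM, in the range 600 nM to 7000 nM, with a real chance that only a limit is reported.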

Compound 4, half-maximal inhibitory concentration: 452 nM
Compound 4: middle estimate off by 4.4-fold (0.65 log units), on the high side; measured number outside the range, below it.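

In this assay, a 1.2-fold higher number from compound 3 to compound 4 (0.07 log units; within the scatter) stays within the scatter, so ethyl and phenyl on a saturated chain carbon bound to an oxygen on an aromatic ring cannot be told apart in this pair. The phenyl of the benzyloxy is therefore not required for the large gain seen earlier: an at least 11-fold lower number from compound 1 to compound 4 (1.04 log units; beyond the scatter), and propoxy matches benzyloxy in holding that gain. This step has a limit at one end, so it gives a bound and not a size: the limit of > 5000 nM in this assay, at which 2 of the 4 values shown sit.

Propoxy replaces ethyl in a single change, which leaves open whether the oxygen on the aromatic ring or the length of the chain carries the step, a question that methoxy or butyl on the same aromatic carbon would address. As far as these compounds go, the step from compound 1 to compound 2 cannot be read, as both values are limits, and it remains open how a longer chain such as hexyloxy, or a chain carrying an amine or a carboxylic acid, would fare at this position.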